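Indolyl Replaces Oxadiazolylphenyl on a Shared Biaryl Amide

This account rests on a few compounds, and the source may have more. Where it says the series, first, only, none or still open, it means among the compounds named here.

In an ADME assay on Raji cells (Homo sapiens) for cytotoxicity, read by CellTiter-Glo and resazurin assay, with a stated time of 72 h (a lower number here means that less compound is needed, a higher number that more compound is needed for the effect), compound 2 `CCOC(=O)CCCCCOc1cccc(CN(C(=O)c2ccc(-c3cccc(-c4nnc(C)o4)c3)cc2)C(C)C)c1` gives only a limit, > 26000 nM, so its place among the numbers shown is known merely as a bound. Compound 1 `CCOC(=O)CCCCCOc1cccc(CN(C(=O)c2ccc(-c3cccc(OCC(C)C)c3)cc2)C(C)C)c1` likewise reaches only a limit in this assay, > 26000 nM. The step that the two limits leave unreadable from compound 1 to compound 2 stays unreadable, as the limit of > 26000 nM in this assay, at which 2 of the 2 values shown sit, shows. Compound 3 `CCOC(=O)CCCCCOc1cccc(CN(C(=O)c2ccc(-c3ccc4[nH]ccc4c3)cc2)C(C)C)c1` has not yet been measured in this assay; it differs from compound 2 by 1H-indol-5-yl in place of 3-(5-methyl-1,3,4-oxadiazol-2-yl)phenyl on an aromatic carbon. Among the measured compounds shown here, the single measured step bears on this change only in that neither of its ends is a number, so no size and no direction can be drawn from it, and no movement beyond the scatter is expected. Compound 3 is therefore expected to stay at the same bound, with an estimated step that the limit leaves unreadable from compound 2 to compound 3. The estimate for compound 3 in this assay is 40000 nM, within a range from 15000 nM to 150000 nM.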

Compound 3, half-maximal effective concentration: > 26000 nM
Compound 3 ended at the assay's limit (the forecaster's own chance of this, stated with the estimate: 85%); the middle value does not contradict the limit.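

Compound 3 also stops at a limit in this assay, so no new step can be read among compound 1, compound 2 and compound 3: the limit of > 26000 nM in this assay, at which 3 of the 3 values shown sit.

The compounds shown leave open whether exchanging these groups on the shared core changes the half-maximal effective concentration at all, and in which direction.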